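Amine tail variation on the quinoline ether urea series

A few compounds are considered here, and "the series" means these few. Any claim that something is new, unique, unknown or untested is made for them only; others in the source may bear on it.

Measured compounds:
- compound 1, `CCN1CCN(CCCOc2cc3nccc(Oc4c(F)cc(NC(=O)NN5C(=O)CSC5c5c(F)cccc5F)cc4F)c3cc2OC)CC1`: 73 nM
- compound 2, `CCN(CC)CCCOc1cc2nccc(Oc3c(F)cc(NC(=O)NN4C(=O)CSC4c4c(F)cccc4F)cc3F)c2cc1OC`: 91 nM
- compound 3, `COc1cc2c(Oc3c(F)cc(NC(=O)NN4C(=O)CSC4c4c(F)cccc4F)cc3F)ccnc2cc1OCCCN1CCC(N2CCCCC2)CC1`: 280 nM

In a functional assay on HT-29 cells (Homo sapiens) for antiproliferative activity, read by MTT assay, with a stated time of 72 h (on this read-out lower numbers stand for stronger inhibition and higher numbers for weaker inhibition), compound 3 gives the highest number of the three; its nearest neighbour is compound 2 (a 3.1-fold higher number from compound 2 to compound 3 (0.49 log units; beyond the scatter)) and its furthest is compound 1 (a 3.8-fold higher number from compound 1 to compound 3 (0.58 log units; beyond the scatter)). Compound 4, `CCN1CCN(CCCCOc2cc3nccc(Oc4c(F)cc(NC(=O)NN5C(=O)CSC5c5c(F)cccc5F)cc4F)c3cc2OC)CC1`, differs from compound 3 by (4-ethylpiperazin-1-yl)methyl in place of 4-(piperidin-1-yl)piperidin-1-yl on a saturated chain carbon, three bonds along the chain from an oxygen on an aromatic ring. It therefore carries the amine of compound 1 on a chain one carbon longer; the two steps above are the ones that bear on the change, both modest and both running toward compound 3. Reversing them, the expected step is downward, a 2.8-fold lower number from compound 3 to compound 4 (0.45 log units; beyond the scatter), with the longer chain an unknown not covered by any measured pair. Compound 4 is estimated at 100 nM, range 40 nM to 250 nM.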

Compound 4, half-maximal inhibitory concentration: 830 nM
Beside the measured number, compound 4's estimate is 8.3-fold (0.92 log units) below it; measured number above the stated range.
By their numbers in this assay, from the lowest: compounds 1 and 2 (each within the scatter of the next); then compound 3; then compound 4.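

In this assay, within the data shown here, one added chain carbon with the 4-ethylpiperazine amine retained gives an 11-fold higher number from compound 1 to compound 4 (1.06 log units; beyond the scatter), the only large step in the set and larger than either amine swap on the shorter chain. Compound 4 also falls behind the other two shorter-chain compounds, with a 9.1-fold higher number from compound 2 to compound 4 (0.96 log units; beyond the scatter) and a 3.0-fold higher number from compound 3 to compound 4 (0.47 log units; beyond the scatter), so chain length at this position matters at least as much as the amine in these compounds. No available data explain this loss.

Going by these compounds, whether diethylamino or 4-(piperidin-1-yl)piperidin-1-yl would respond in the same way on the longer chain remains open. So does the effect of a shorter chain or a morpholine tail.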